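The source may hold more compounds than are shown below. What is called first, only, known or untested is meant among the compounds shown, and "the series" means these compounds.

Compound 3 `COc1cccc(COc2ccc(-c3nn(CCC#N)c(=S)o3)cc2)c1` stands second highest of the three numbers measured in an assay for inhibition of Amine oxidase [flavin-containing] B (Rattus norvegicus); on this read-out higher numbers stand for weaker inhibition and lower numbers for stronger inhibition. In this assay compound 3 gives 100 nM. The nearest of the three is compound 1 `Cc1cccc(COc2ccc(-c3nn(CCC#N)c(=O)o3)cc2)c1`, which in this assay gives 8 nM; the furthest is compound 2 `N#CCCn1nc(-c2ccc(OCc3ccc([N+](=O)[O-])cc3)cc2)oc1=O`, which in this assay gives 5500 nM. Compound 4 `COc1ccc(COc2ccc(-c3nn(CCC#N)c(=S)o3)cc2)cc1` differs from compound 3 in a single respect: 4-methoxyphenyl in place of 3-methoxyphenyl on a saturated chain carbon bound to an oxygen on an aromatic ring. For the measured compounds named here, only one measured step touches the same place on the molecule. That is a 690-fold higher number from compound 1 to compound 2 (2.84 log units; beyond the scatter), which combined a shift of the substituent around the ring with a swap of methyl for nitro, so it bears on compound 4 only loosely. Nothing measured separates the two parts of that change, so the expectation rests on the fact that the one known move, to 4-nitrophenyl, weakened inhibition heavily. A weaker result is therefore expected for compound 4, though by a smaller margin than that earlier step, with the estimated step being a 4.0-fold higher number from compound 3 to compound 4 (0.60 log units; beyond the scatter). The value expected for compound 4 in this assay is 400 nM, with a plausible range from 60 nM to 3000 nM.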

Compound 4, half-maximal inhibitory concentration: 910 nM
Beside the measured number, compound 4's estimate is 2.3-fold (0.36 log units) below it; measured number inside the range.
By their numbers in this assay, from the lowest: compound 1; then compound 3; then compound 4; then compound 2.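

With the same atoms joined differently, 4-methoxyphenyl in place of 3-methoxyphenyl gives a 9.1-fold higher number from compound 3 to compound 4 (0.96 log units; beyond the scatter) in this assay, so the placement of the methoxy group alone weakens inhibition by more than the usual scatter. For the compounds shown here, the only earlier step at this place, a 690-fold higher number from compound 1 to compound 2 (2.84 log units; beyond the scatter), changed methyl to nitro and moved the substituent around the ring in one go, whereas this step isolates a move of the substituent and shows that such a move can matter here even when the group stays the same. This step is clearly the smaller of the two, but it sits on a different core and does not split the earlier change into separate parts, and no measurement is available to explain why the 4-methoxyphenyl compound is the weaker inhibitor.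

From the compounds shown here alone, it remains open whether the same move from a 3-substituted to a 4-substituted phenyl would cost a similar amount on the core of compound 1, or with groups other than methoxy. How 2-methoxyphenyl, 4-fluorophenyl or 4-aminophenyl would behave on the same saturated chain carbon is also unknown from these compounds.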